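The source may hold more compounds than are shown below. What is called first, only, known or untested is meant among the compounds shown, and "the series" means these compounds.

Compound 1 `COc1ccc(-c2ccc3ncn(-c4cc(OC)c(OC)c(OC)c4)c3c2)cc1O` is the strongest of the three measured compounds in a functional assay on A549 cells (Homo sapiens) for antiproliferative activity, read by MTT assay, with a stated time of 72 h (a higher number here means a weaker inhibitor, a lower number a stronger inhibitor), where compound 1 gives 200 nM. Compound 2 `COc1cc(-n2cnc3ccc(-c4ccc([N+](=O)[O-])cc4)cc32)cc(OC)c1OC` gives 8940 nM in this assay, and compound 3 `COc1cc(-n2cnc3ccc(-c4cccc(C)c4C)cc32)cc(OC)c1OC` gives 9250 nM. Both of those differ from compound 1 only in the ring that hangs from the shared core: a 45-fold higher number from compound 1 to compound 2 (1.65 log units; beyond the scatter) and a 46-fold higher number from compound 1 to compound 3 (1.67 log units; beyond the scatter), while the two weaker compounds sit together, a 1.0-fold higher number from compound 2 to compound 3 (0.01 log units; within the scatter).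

Compound 4 `COc1cc(-n2cnc3ccc(-c4ccc(F)cc4)cc32)cc(OC)c1OC` has not been measured. Compared with compound 1 the change is 4-fluorophenyl in place of 3-hydroxy-4-methoxyphenyl on an aromatic carbon. As in compound 2 and compound 3, the hydroxy and methoxy groups of compound 1 are gone, and here a single fluorine stands in their place. The two measured steps that remove those groups were both large and both in the weakening direction, so a step of similar size is expected for compound 4, again with a higher number.

The estimate for compound 4 in this assay is 5000 nM, expected between 1500 nM and 15000 nM, which would mean an expected step of a 25-fold higher number from compound 1 to compound 4 (1.40 log units; beyond the scatter).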

Compound 4, half-maximal inhibitory concentration: 6740 nM
For compound 4 the middle estimate is 1.3-fold (0.13 log units) below the measured one, within the range that was stated.
By their numbers in this assay, from the lowest: compound 1; then compounds 4, 2 and 3 (each within the scatter of the next).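

In this assay, a third replacement of the 3-hydroxy-4-methoxyphenyl ring also gives a large weakening (a 34-fold higher number from compound 1 to compound 4 (1.53 log units; beyond the scatter)), yet compound 4 cannot be told apart from the other two weak compounds (a 1.4-fold lower number from compound 3 to compound 4 (0.14 log units; within the scatter); a 1.3-fold lower number from compound 2 to compound 4 (0.12 log units; within the scatter)). Fluoro in place of nitro therefore makes no readable difference here, and neither does 4-fluorophenyl in place of 2,3-dimethylphenyl, so three differently substituted rings all fall close together and far from compound 1. No measurement at hand explains this shared loss.

Within the data shown here, no compound here keeps only the hydroxy or only the methoxy of compound 1, so which of the two matters more stays open. From the compounds shown here alone, it is also open whether another group on this ring, such as an amine or a carboxylic acid, could bring back the strength of compound 1.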